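Chloro on the fused core: compound 2 to compound 4

The compounds below may be only part of what the source reports. "The series", "measured", "known", "first", "only" and "open" are said of these compounds alone.

Measured compounds in this series:
compound 1, `ClCc1ccc(Cn2cnc3c(Cl)ncnc32)cc1`, 1380 nM
compound 2, `ClCc1cccc(Cn2cnc3ncnc(Cl)c32)c1`, 17400 nM
compound 3, `ClCc1cccc(Cn2cnc3c(Cl)ncnc32)c1`, 19500 nM

In a functional assay on A549 cells (Homo sapiens) for cytotoxicity, read by sulforhodamine B assay, with a stated time of 48 h (on this read-out lower numbers stand for stronger inhibition of growth and higher numbers for weaker inhibition of growth), compound 2 gives 17400 nM, the second highest of the three numbers. Its nearest neighbour is compound 3, which gives 19500 nM; the two lie within the scatter of each other, so no order between them is claimed. Compound 1 gives 1380 nM, a lower number than compound 2 by a margin beyond the scatter.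

Compound 4, `ClCc1cccc(Cn2cnc3nc(Cl)nc(Cl)c32)c1`, is not yet measured. It differs from compound 2 by chloro in place of hydrogen on an aromatic carbon. Within the data shown here, no measured pair in this set carries that change, so the step from compound 2 to compound 4 has no precedent here; the only separation seen so far, between compound 1 and compounds 2 and 3, lies on the benzyl part and not on the fused core. The expectation is therefore a step of modest size at most, a 1.5-fold lower number from compound 2 to compound 4 (0.16 log units; within the scatter), with no direction claimed beyond the scatter. Compound 4 is estimated at 12000 nM, in a range from 4000 nM to 40000 nM.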

Compound 4, concentration for 50% growth inhibition: 12000 nM
Estimate against measurement, compound 4: no gap at the digits printed, and the stated range covers the measured number.
By their numbers in this assay, from the lowest: compound 1; then compounds 4, 2 and 3 (each within the scatter of the next).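

In this assay, among these compounds, the series now has a first step at this aromatic carbon, between two ring nitrogen atoms: a 1.5-fold lower number from compound 2 to compound 4 (0.16 log units; within the scatter). The earlier compounds shown here all carry hydrogen here and so could not speak to this place, whereas this step shows that, with the rest of compound 2 unchanged, this carbon accepts chloro in place of hydrogen without a step beyond the scatter, at least for this one group and this one read-out. No supporting measurement is available to account for the size of this step.

Open is whether a different group at the same carbon, such as an amine, a methoxy group or a carboxylic acid, would give a step beyond the scatter, since chloro is the only replacement for hydrogen shown here. Also open, from the compounds shown here alone, is whether the same change on the core of compound 1, whose number of 1380 nM lies much lower, would give a step of similar size, as one step on one background cannot show whether the result carries over.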